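The compounds below may be only part of what the source reports. "The series", "measured", "known", "first", "only" and "open" are said of these compounds alone.

In a functional assay on MCF7 cells (Homo sapiens) for antiproliferative activity, read by fluorescence and SYBR Green assay, with a stated time of 24 h (a higher number here means a weaker inhibitor, a lower number a stronger inhibitor), compound 1 `COc1ccc2c(c1)CCCN2S(=O)(=O)c1ccc(N2CCCC2=O)cc1` gives 25 nM. Compound 2 `Cc1ccc2c(c1)CCCN2S(=O)(=O)c1ccc(N2CCCC2=O)cc1` gives 15 nM. Compound 3 `O=C1CCCN1c1ccc(S(=O)(=O)N2CCCc3ccccc32)cc1` gives 17 nM.

Compound 3 holds the second highest of the three numbers; its nearest neighbour is compound 2 and its furthest is compound 1, and both gaps lie within the scatter. Compound 4 `CC(C)(C)c1ccc2c(c1)CCCN2S(=O)(=O)c1ccc(N2CCCC2=O)cc1` differs from compound 3 by tert-butyl in place of hydrogen on an aromatic carbon. The measured steps at that aromatic carbon are a 1.5-fold lower number from compound 1 to compound 3 (0.17 log units; within the scatter) and a 1.1-fold higher number from compound 2 to compound 3 (0.05 log units; within the scatter), neither beyond the scatter. Among the measured compounds shown here, no measured step covers the tert-butyl group itself, so the account rests on a wider range. A step of a 1.3-fold higher number from compound 3 to compound 4 (0.11 log units; within the scatter) is therefore expected, not beyond the scatter. For compound 4 the estimate in this assay is 22 nM, expected to fall between 8 nM and 70 nM.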

Compound 4, half-maximal inhibitory concentration: 318 nM
The estimate for compound 4 lay 14-fold (1.16 log units) below the measured number, outside the stated range (above it).
By their numbers in this assay, from the lowest: compounds 2, 3 and 1 (each within the scatter of the next); then compound 4.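

At this aromatic carbon methoxy, methyl and hydrogen had all stayed within the scatter of one another in this assay, so tert-butyl is the first group shown there to shift the number beyond it, with a 19-fold higher number from compound 3 to compound 4 (1.27 log units; beyond the scatter) and a 21-fold higher number from compound 2 to compound 4 (1.33 log units; beyond the scatter) and a 13-fold higher number from compound 1 to compound 4 (1.10 log units; beyond the scatter). The position therefore accepts these three earlier groups alike but not every group, and the weaker result holds against all three compounds. Nothing available here accounts for this loss.

Among the compounds shown here, it remains open whether an ethyl or isopropyl group at this carbon would stay with the earlier compounds or already follow compound 4, and how an amine or a carboxylic acid there would read.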